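(2-Fluorophenyl)carbonyl in place of 2-methylphenyl, compound 1 to compound 3

The compounds below may be only part of what the source reports. "The series", "measured", "known", "first", "only" and "open" are said of these compounds alone.

Compound 1 `Cc1ccccc1NNC(=O)c1ccc(NS(=O)(=O)c2cnc(O)nc2O)cc1` is one of two measured compounds. In a functional assay on OVCAR-3 cells (Homo sapiens) for antiproliferative activity, read by MTT assay, with a stated time of 24 h (on this read-out lower numbers stand for stronger inhibition and higher numbers for weaker inhibition), compound 1 gives > 20000 nM, which is a limit of the assay and not a number. Compound 1 therefore stands at the limit of > 20000 nM in this assay, at which 1 of the 2 values shown sits. The other measured compound is compound 2 `O=C(NNc1ccccc1F)c1ccccc1NS(=O)(=O)c1cnc(O)nc1O`; in this assay compound 2 gives 9570 nM. Among the measured compounds shown here, no step between measured compounds that differ in one place is available, so no measured change can be carried over.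

Compound 3 `O=C(NNC(=O)c1ccccc1F)c1ccc(NS(=O)(=O)c2cnc(O)nc2O)cc1` differs from compound 1 in a single place: (2-fluorophenyl)carbonyl in place of 2-methylphenyl on an amine nitrogen. Compound 1 shows only a limit, so no measured change can anchor the expectation. The step of an at least 1.3-fold lower number from compound 1 to compound 3 (0.12 log units; that floor lies within the scatter) that is expected here is modest, leaning towards stronger inhibition but possibly not beyond the scatter. For compound 3 in this assay the estimate is 15000 nM, with a range from 5000 nM to 40000 nM.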

Compound 3, half-maximal inhibitory concentration: 16000 nM
Compound 3: the middle estimate sits 1.1-fold (0.03 log units) below what was measured; the range from low to high includes it.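

Among the compounds shown here, on this amine nitrogen, the change from 2-methylphenyl to (2-fluorophenyl)carbonyl gives the first measured number for this series of compounds with this substitution pattern in this assay: compound 3 reads within the range of the assay. The change amounts to an at least 1.2-fold lower number from compound 1 to compound 3 (0.09 log units; that floor lies within the scatter), so the compounds shown establish no gain beyond the scatter. The reading for compound 1 is a limit of the assay and not a number: the limit of > 20000 nM in this assay, at which 1 of the 3 values shown sits.

From the compounds shown here alone, the true size of the step therefore stays open, and so does the question of whether the carbonyl or the fluorine accounts for any of it, since the two enter together. How a benzoyl group without fluorine or a plain acetyl group would read on this nitrogen remains unknown from the compounds shown.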